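The source may report more compounds than this note shows. Statements on the series, on what has been measured and on what is new or still open speak of the compounds shown alone.

Measured so far in an ADME assay on microsomes from liver (Rattus norvegicus) for metabolic stability, read by mass spectrometry, using NADPH, with a stated time of 10 min; a higher number here means that more of the compound is left, a lower number that less of the compound is left:
Compound 1, `CCCCc1[nH]c(=O)c(-c2nnc(Cc3ccc(Cl)cc3)o2)c(O)c1-c1c(OC)cccc1OC`, gives 22%.
Compound 2, `COc1cccc(OC)c1-c1c(C2CCCC2)[nH]c(=O)c(-c2nnc(Cc3ccc(Cl)cc3)o2)c1O`, gives 66%.
Compound 3, `COc1cccc(OC)c1-c1c(C2CC2)[nH]c(=O)c(-c2nnc(Cc3ccc(Cl)cc3)o2)c1O`, gives 51%.

Compound 3 stands second highest of the three numbers. The nearest value is that of compound 2, with a number 15 percentage points lower from compound 2 to compound 3 (beyond the scatter); the furthest is that of compound 1, with a number 29 percentage points higher from compound 1 to compound 3 (beyond the scatter).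

Compound 4, `COCCc1[nH]c(=O)c(-c2nnc(Cc3ccc(Cl)cc3)o2)c(O)c1-c1c(OC)cccc1OC`, is the compound not yet measured. It differs from compound 3 in one place: 2-methoxyethyl in place of cyclopropyl on an aromatic carbon.

For the measured compounds named here, no measured step exchanges a cyclopropyl group for a 2-methoxyethyl group, so the closest guides are the steps that swap a chain for a ring at the same carbon. Leaving the butyl chain for a ring raised the number both times: a number 29 percentage points higher from compound 1 to compound 3 (beyond the scatter) and a number 44 percentage points higher from compound 1 to compound 2 (beyond the scatter). Between the two rings the difference was smaller: a number 15 percentage points lower from compound 2 to compound 3 (beyond the scatter). Going by the values given here, compound 4 carries a chain again, though a chain containing an oxygen, which has no counterpart among the measured compounds and widens the uncertainty. If the chain-versus-ring pattern holds, the step from compound 3 is expected to be downward and beyond the scatter, a number 21 percentage points lower from compound 3 to compound 4 (beyond the scatter). Compound 4 is therefore estimated at 30%, within a range from 14% to 50%.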

Compound 4, percent of the compound remaining in the Rattus norvegicus assay: 73%
Compound 4: middle estimate off by 43 percentage points, on the low side, outside the stated range (above it).
By their numbers in the Rattus norvegicus assay, from the lowest: compound 1; then compound 3; then compounds 2 and 4 (each within the scatter of the next).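

For the compounds shown here, in the Rattus norvegicus assay, the earlier compounds made a ring at this carbon look better than a chain, but an open chain can do just as well here, as there is a number 22 percentage points higher from compound 3 to compound 4 (beyond the scatter) and a number 7 percentage points higher from compound 2 to compound 4 (within the scatter). Chain against ring is therefore too coarse a description of this position, since the two chains shown stand far apart, with a number 51 percentage points higher from compound 1 to compound 4 (beyond the scatter), and that step is a single exchange of methoxy for ethyl on the saturated chain. The change from cyclopropyl to 2-methoxyethyl also shows up in a second read-out, where in a physicochemical assay for solubility, in phosphate buffer, with a stated time of 24 h, at pH 7.4 (on this read-out lower numbers stand for lower solubility and higher numbers for higher solubility), compound 3 gives 12 ug/mL and compound 4 gives 73 ug/mL.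

From the compounds shown here alone, how a 3-methoxypropyl chain or a 2-aminoethyl chain would behave at this carbon stays open, so it cannot yet be told whether the oxygen, its place in the chain or the chain length decides the outcome. The solubility comparison rests on a single pair and cannot show whether it has any connection with the amount of compound left in the microsomes: the measured solubility of compound 3, 12 ug/mL, and of compound 4, 73 ug/mL, a 6.1-fold higher number (0.78 log units; beyond the scatter)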